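Para Substituent Swap on the Anilino Core

The source may report more compounds than this note shows. Statements on the series, on what has been measured and on what is new or still open speak of the compounds shown alone.

Two compounds of the series have numbers in an assay on mitochondria from L6 cells (Rattus norvegicus) for activation, with a stated time of 90 min; on this read-out lower numbers stand for an effect already at smaller amounts and higher numbers for an effect only at larger amounts of compound. Compound 1 `Oc1nc2nonc2nc1Nc1ccc(OC(F)(F)F)cc1Cl` gives 1400 nM in this assay. Compound 2 `Oc1nc2nonc2nc1Nc1ccc(OCc2ccccc2)cc1` gives 2400 nM in this assay, the highest of the two numbers, though its gap to compound 1 lies within the scatter, so no order between them can be read. Within the data shown here, no step between measured compounds is available, and nothing here speaks to the direction of the change to compound 3 `CC(C)(C)c1ccc(Nc2nc3nonc3nc2O)cc1`, which differs from compound 2 by tert-butyl in place of benzyloxy on an aromatic carbon. With only the two values of compound 1 and compound 2 as a guide, both within the scatter of each other, no move beyond the scatter is expected, and the estimated step from compound 2 is a 1.2-fold lower number from compound 2 to compound 3 (0.08 log units; within the scatter). Compound 3 is expected to give about 2000 nM in this assay, with a range from 700 nM to 6000 nM.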

Compound 3, half-maximal effective concentration: 3900 nM
Beside the measured number, compound 3's estimate is 2.0-fold (0.29 log units) below it; the measured number falls inside the stated range.
By their numbers in this assay, from the lowest: compounds 1, 2 and 3 (each within the scatter of the next, the first and the last beyond it).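

In this assay, among these compounds, tert-butyl in place of benzyloxy on an aromatic carbon, para to a large group, gives a 1.6-fold higher number from compound 2 to compound 3 (0.21 log units; within the scatter), the first comparison that changes one place only. At this position, then, the benzyloxy group with its aromatic ring and hydrogen-bond acceptor can give way to tert-butyl, which has neither, without a move that can be told from the scatter. No supporting measurement bears on this step.

On these data alone, whether an amine or a carboxylic acid at this place would move the number beyond the scatter remains open. The contribution of the chlorine in compound 1 also remains open, as no pair of compounds shown differs there alone.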